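A Pyridyl Amide Variant in a Weakly Active Series

The compounds below may be only part of what the source reports. "The series", "measured", "known", "first", "only" and "open" are said of these compounds alone.

Of the compounds shown here, three built on a shared core have been tested in a functional assay on A549 cells (Homo sapiens) for antiproliferative activity, read by MTT assay, with a stated time of 72 h; on this read-out lower numbers stand for stronger inhibition and higher numbers for weaker inhibition. Compound 1 `O=C(Nc1ccc(Cl)c(-c2nnc3c(Cl)cccn23)c1)c1ccc(C(F)(F)F)cc1F` sits at the limit of the assay, > 100000 nM, which is a limit and not a number. Compound 3 `CS(=O)(=O)c1ccc(C(=O)Nc2ccc(Cl)c(-c3nnc4c(Cl)cccn34)c2)c(Cl)c1` likewise reaches only a limit, > 100000 nM. For the measured compounds named here, compound 2 `O=C(Nc1ccc(Cl)c(-c2nnc3c(Cl)cccn23)c1)c1cccc(Cl)c1` alone yields a number, 52700 nM, and so it stands as the single measured value. Compound 1 and compound 3 both sit at the limit of the assay (the limit of > 100000 nM in this assay, at which 2 of the 3 values shown sit).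

Compound 4 `O=C(Nc1ccc(Cl)c(-c2nnc3c(Cl)cccn23)c1)c1cccnc1Cl` has not yet been measured. It differs from compound 2 in one place: 2-chloropyridin-3-yl in place of 3-chlorophenyl on a carbonyl carbon, in words 2-chloropyridin-3-yl in place of 3-chlorophenyl on a carbonyl carbon. Going by the values given here, no pair of measured compounds differing in a single place exists in this set, so the size of such a step has no precedent here. The expected step in this assay is small, a 1.1-fold higher number from compound 2 to compound 4 (0.06 log units; within the scatter), not clearly beyond the usual scatter in either direction. Compound 4 is therefore estimated at 60000 nM, with a range from 20000 nM to 150000 nM, and a real chance that the assay returns only a limit.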

Compound 4, half-maximal inhibitory concentration: 35800 nM
For compound 4 the middle estimate is 1.7-fold (0.22 log units) above the measured one; measured number inside the range.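

In this assay, for the compounds shown here, putting 2-chloropyridin-3-yl in place of 3-chlorophenyl on a carbonyl carbon gives a 1.5-fold lower number from compound 2 to compound 4 (0.17 log units; within the scatter), the first step in this set that can be read between two numbers. At this position, then, an aromatic ring with one hetero atom and one hydrogen-bond acceptor can replace the ring of carbon only without a change beyond the scatter, and the assay still returns a number. Compound 1 and compound 3 remain limits and not numbers, so no step can be read from them: the limit of > 100000 nM in this assay, at which 2 of the 4 values shown sit.

The compounds shown leave open whether a pyridin-3-yl ring carrying an amine or a methoxy group in place of the chlorine would read any differently. From the compounds shown here alone, whether any group on this carbonyl carbon can move the number beyond the scatter also remains open.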